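Sulfonamide nitrogen substituent: cyclopropyl to cyclobutyl

The compounds below may be only part of what the source reports. "The series", "measured", "known", "first", "only" and "open" are said of these compounds alone.

Of the compounds shown here, two have been measured in a functional assay on MIA PaCa-2 cells (Homo sapiens) for inhibition, read by MTT assay, with a stated time of 3 days; on this read-out lower numbers stand for stronger inhibition and higher numbers for weaker inhibition. Compound 1 `CCN(CC)S(=O)(=O)c1ccc(S(=O)(=O)N2CCC[C@@H](C(=O)N[C@@H]3CCN(C(=O)OC(C)(C)C)C3)C2)cc1` gives 500 nM in this assay. Compound 2 `CC(C)c1noc(N2CCN(C(=O)[C@@H]3CCCN(S(=O)(=O)c4ccc(S(=O)(=O)NC5CC5)cc4)C3)CC2)n1` gives 300 nM in this assay. Compound 2 thus has the lower of the two numbers, but compound 1 is within the scatter of it, so the two cannot be told apart on this read-out. The two structures differ in more than one place, so no single step can be read between them.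

Compound 3 `CC(C)c1noc(N2CCN(C(=O)[C@@H]3CCCN(S(=O)(=O)c4ccc(S(=O)(=O)NC5CCC5)cc4)C3)CC2)n1` has not yet been measured. It differs from compound 2 in one place: cyclobutyl in place of cyclopropyl on a sulfonamide nitrogen. Within the data shown here, the change is the smallest kind of ring enlargement, at a position remote from the rest of the shared core, and nothing among the measured compounds speaks to what such a change does here. Compound 3 is therefore expected to sit close to compound 2, with an estimate of 300 nM and a range from 120 nM to 750 nM. The step this estimate means, no change at the digits printed from compound 2 to compound 3 (within the scatter), is expected to stay within the usual scatter, in no particular direction.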

Compound 3, half-maximal inhibitory concentration: 200 nM
Compound 3: middle estimate off by 1.5-fold (0.18 log units), on the high side, within the range that was stated.
By their numbers in this assay, from the lowest: compounds 3, 2 and 1 (each within the scatter of the next, the first and the last beyond it).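

In this assay, replacing cyclopropyl with cyclobutyl on a sulfonamide nitrogen gives a 1.5-fold lower number from compound 2 to compound 3 (0.18 log units; within the scatter), so the two compounds cannot be told apart on this read-out. Among these compounds, this is the first comparison in the set in which only one place changes, and it shows that, at this sulfonamide nitrogen, the three-membered ring can give way to the four-membered ring without a step beyond the scatter. No measurement at hand bears on why the two compounds read alike.

The compounds shown leave open whether cyclopentyl, a longer chain, or a group carrying an amine or a carboxylic acid would also keep the number within the scatter of compound 2 when placed on this sulfonamide nitrogen. Compound 1 carries two ethyl groups on its sulfonamide nitrogen but also differs from compound 2 and compound 3 elsewhere, so it cannot show what those ethyl groups do at this position.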